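The compounds below may be only part of what the source reports. "The series", "measured", "known", "first", "only" and "open" are said of these compounds alone.

Series notes. Within the data shown here, compound 3 `Cc1ccsc1C1=NNC(c2ccc(N3CCCCC3)cc2)C1` gives the lowest number of the three measured so far in an ADME assay on Vero cells (Chlorocebus sabaeus) for cytotoxicity, with a stated time of 5 days; a higher number here means a weaker inhibitor, a lower number a stronger inhibitor: compound 3 gives 11400 nM, compound 1 `O=C(/C=C/c1ccc(N2CCCCC2)cc1)c1ccsc1` gives 34400 nM, and compound 2 `Cc1csc(C(=O)/C=C/c2ccc(N3CCCCC3)cc2)c1` gives 56300 nM. The next compound 4 `Ic1ccc(C2=NNC(c3ccc(N4CCCCC4)cc3)C2)s1` carries 5-iodothiophen-2-yl in place of 3-methylthiophen-2-yl on a carbon with a double bond to nitrogen. Among the measured compounds shown here, the only measured step of a related kind, an exchange of one five-membered aromatic ring with one hetero atom for another, is a 1.6-fold higher number from compound 1 to compound 2 (0.21 log units; within the scatter); it sits on a carbonyl carbon rather than on the core of compound 3, so it bears only loosely on the present change. On that basis no step beyond the scatter is expected, and the estimated step is a 1.1-fold higher number from compound 3 to compound 4 (0.02 log units; within the scatter). For compound 4 the expected value in this assay is 12000 nM, with a range from 5000 nM to 30000 nM.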

Compound 4, half-maximal inhibitory concentration: 15900 nM
For compound 4 the middle estimate is 1.3-fold (0.12 log units) below the measured one, and the stated range covers the measured number.
By their numbers in this assay, from the lowest: compounds 3 and 4 (each within the scatter of the next); then compounds 1 and 2 (each within the scatter of the next).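

In this assay, the step on the core of compound 3, at a carbon with a double bond to nitrogen of the five-membered non-aromatic ring, is a 1.4-fold higher number from compound 3 to compound 4 (0.14 log units; within the scatter). This position therefore accepts 5-iodothiophen-2-yl in place of 3-methylthiophen-2-yl without a change beyond the scatter, a result the earlier step on a carbonyl carbon could not show. No measurement bearing on the reason for this result is available. The roles of the iodine and the methyl group cannot be separated here, since the two rings differ in both substituent and substitution pattern. From the compounds shown here alone, whether a carboxylic acid or an amine on the thiophene ring would give a similar number remains open.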